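The compounds below may be only part of what the source reports. "The series", "measured", "known", "first", "only" and "open" are said of these compounds alone.

Measured compounds:
- Compound 1, `CCN(Cc1cc[nH]n1)C(=O)COc1ccc(C)cc1`: "not active" (no number reported)
- Compound 2, `Cc1ccc(OCC(=O)N(Cc2cccs2)C2CCCCC2)cc1`: 40000 nM
- Compound 3, `CCN(Cc1cccs1)C(=O)C(C)Oc1ccc(C)cc1`: 889 nM

In an assay on HEK293 cells for agonist activity at transient receptor potential cation channel subfamily M member 8 (Homo sapiens), read by fluorescence and calcium flux, with a stated time of 15 min (a higher number here means that more compound is needed for the effect, a lower number that less compound is needed), compound 2 gives 40000 nM, the highest of the two numbers reported. Its nearest neighbour in this set is compound 3, which in this assay gives 889 nM, a far lower number, well beyond the scatter. Compound 1 carries no number at all in this assay; it was reported as not active.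

The next compound, compound 4, `Cc1ccc(OCC(=O)N(Cc2cccs2)c2ccn[nH]2)cc1`, has not yet been measured. It differs from compound 2 in one place: 1H-pyrazol-5-yl in place of cyclohexyl on an amide-type nitrogen. Going by the values given here, no directly comparable pair has yet been measured, so the size of this step is open. Among the compounds with values here, compound 2 already stands at the weak end of the series, and the only other compound bearing a pyrazole group, compound 1, was reported without any number. The step from compound 2 to compound 4 is therefore expected to be small or to move toward a still higher number, a 1.8-fold higher number from compound 2 to compound 4 (0.24 log units; within the scatter), with a real chance that only a limit is reported. Compound 4 is estimated at 70000 nM, within a range of 20000 nM to 250000 nM.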

Compound 4, half-maximal effective concentration: 0.2 nM
Compound 4: middle estimate off by 350000-fold (5.54 log units), on the high side; the whole stated range lies above it.
By their numbers in this assay, from the lowest: compound 4; then compound 3; then compound 2.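

In this assay, the group on the amide-type nitrogen proves to be a highly sensitive place in this series: 1H-pyrazol-5-yl in place of cyclohexyl gives a 200000-fold lower number from compound 2 to compound 4 (5.30 log units; beyond the scatter) and lies beyond the scatter. The earlier compounds shown here formed no pair differing in one place, so they could not show how much this single change can move the read-out. The entering group differs from cyclohexyl in ring size, aromaticity, nitrogen content and hydrogen-bond donor and acceptor counts, and no evidence is available to separate these differences or explain the step.

The compounds shown do not reveal how a phenyl, 1-methyl-1H-pyrazol-5-yl or imidazolyl group would behave on this nitrogen. They therefore leave open whether the result depends on the pyrazole ring itself or on the hydrogen on its nitrogen.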